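This account rests on a few compounds, and the source may have more. Where it says the series, first, only, none or still open, it means among the compounds named here.

Working notes on the series.

Compound 2 `N#CC1=C(N)N(c2ccc(S(N)(=O)=O)cc2)C2=C(CCCC2)C1c1ccccc1O` is measured in a functional assay on Ehrlich cells (Mus musculus) for cytotoxicity, read by trypan blue exclusion, with a stated time of 2 h, tested at 10 ug/mL (a lower number here means a weaker effect, a higher number a stronger effect of the compound at the concentration tested), at 10%. Among the three numbers so far it is the second highest. Its nearest neighbour is compound 1 `N#CC1=C(N)N(c2ccc(S(N)(=O)=O)cc2)C2=C(CCCC2)C1c1ccccc1`, which in this assay gives 5%, and the step of a number 5 percentage points higher from compound 1 to compound 2 (within the scatter) is within the scatter. Compound 3 `N#CC1=C(N)N(c2ccc(S(N)(=O)=O)cc2)C2=C(CCCC2)C1/C=C/c1ccccc1` stands furthest away, at 50% in this assay; the steps of a number 45 percentage points higher from compound 1 to compound 3 (beyond the scatter) and a number 40 percentage points higher from compound 2 to compound 3 (beyond the scatter) are both large and beyond the scatter, and both belong to the 2-phenylethenyl group on the saturated ring carbon.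

Compound 4 `N#CC1=C(N)N(c2ccc(S(N)(=O)=O)cc2)C2=C(CCCC2)C1c1ccc(Cl)c(Cl)c1` is not yet measured. It differs from compound 2 as follows: 3,4-dichlorophenyl in place of 2-hydroxyphenyl on a saturated ring carbon

Among the compounds with values here, of the measured steps, only the one from compound 1 to compound 2 touches the same aromatic ring, and it shows that adding or removing a hydroxy there stays within the scatter. Within the data shown here, no measured step covers chlorine substituents on this ring, and the large steps to compound 3 concern a different group altogether, so they carry little weight here. For compound 4 a step of a number 2 percentage points higher from compound 2 to compound 4 (within the scatter) in this assay is therefore expected, which is no change beyond the scatter. Compound 4 is estimated at 12% in this assay, with a range from 2% to 30%.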

Compound 4, a percentage reported as activity, at one concentration (the size of the read-out at that concentration, not a potency): 1%
Compound 4: middle estimate off by 11 percentage points, on the high side, and the stated range ends above it.
By their numbers in this assay, from the lowest: compounds 4, 1 and 2 (each within the scatter of the next); then compound 3.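

In this assay, the step of a number 9 percentage points lower from compound 2 to compound 4 (within the scatter) and the step of a number 4 percentage points lower from compound 1 to compound 4 (within the scatter) show that this saturated ring carbon also tolerates 3,4-dichlorophenyl without leaving the scatter, so the three aryl groups seen here, phenyl, 2-hydroxyphenyl and 3,4-dichlorophenyl, cannot be told apart at the one concentration tested. The step of a number 49 percentage points lower from compound 3 to compound 4 (beyond the scatter) adds a third large gap to 2-phenylethenyl, so among these four compounds the high number stands with that group alone and no compound goes against this. Nothing in hand accounts for the gap between the aryl groups and 2-phenylethenyl.

The compounds shown leave open whether the high number depends on the carbon-carbon double bond of 2-phenylethenyl, which a saturated 2-phenylethyl chain would test, or on the terminal phenyl, which a pyridyl ring at the end of the same link would test. They also leave open whether chlorine or hydroxy on the phenyl of 2-phenylethenyl would matter there, given that on the directly attached ring neither moves the number beyond the scatter.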